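Methoxyphenyl for chlorophenyl in a weakly cytotoxic series

This account rests on a few compounds, and the source may have more. Where it says the series, first, only, none or still open, it means among the compounds named here.

Compound 1 `O=C(CN1CCN(c2ccccc2Cl)CC1)N1CCN(c2nnc(-c3ccccc3)c(-c3ccccc3)n2)CC1` gives 263000 nM in a functional assay on MCF7 cells (Homo sapiens) for cytotoxicity, read by MTT assay, with a stated time of 24 h; a higher number here means a weaker inhibitor, a lower number a stronger inhibitor.
Compound 2 `COc1ccc(N2CCN(CC(=O)N3CCN(c4nnc(-c5ccccc5)c(-c5ccccc5)n4)CC3)CC2)cc1` gives > 910000 nM in this assay, which is a limit of the assay and not a number.
Compound 3 `Cc1ccc(-c2nnc(N3CCN(C(=O)CN4CCN(c5ccccc5Cl)CC4)CC3)nc2-c2ccc(C)cc2)cc1` gives 859000 nM in this assay.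

Compound 3 stands at the highest of the two numbers that were reached. Its nearest neighbour is compound 1, whose number sits lower, beyond the scatter; compound 2 gave only a limit.

Compound 4 `COc1ccc(N2CCN(CC(=O)N3CCN(c4nnc(-c5ccc(C)cc5)c(-c5ccc(C)cc5)n4)CC3)CC2)cc1` is not yet measured in this assay. It differs from compound 3 in one place: 4-methoxyphenyl in place of 2-chlorophenyl on an amine nitrogen in a ring. Within the data shown here, one measured step bears directly on this change, the one from compound 1 to compound 2, which gave an at least 3.4-fold higher number from compound 1 to compound 2 (0.53 log units; beyond the scatter). As far as these compounds go, that step ran into (the limit of > 910000 nM in this assay, at which 1 of the 3 values shown sits), so its full size is unknown. Compound 3 already starts close to that limit, so the same change is expected to carry compound 4 past it in this assay.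

The step from compound 3 to compound 4 is therefore estimated as a 2.9-fold higher number from compound 3 to compound 4 (0.46 log units; beyond the scatter) in this assay. Compound 4 is expected to give about 2500000 nM in this assay, within a range from 900000 nM to 8000000 nM, and most likely to be reported as a limit rather than a number.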

Compound 4, half-maximal inhibitory concentration: 53000 nM
For compound 4 the middle estimate is 47-fold (1.67 log units) above the measured one, and the stated range ends above it.
By their numbers in this assay, from the lowest: compound 4; then compound 1; then compound 3. At a limit, above all of these: compound 2.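

In this assay, 4-methoxyphenyl in place of 2-chlorophenyl on the amine nitrogen in the ring gives a 16-fold lower number from compound 3 to compound 4 (1.21 log units; beyond the scatter), so at this position the change does not carry a single direction with it. The earlier pair showed only a rise in the number, whereas this pair shows that the same change can also lower it, and the two steps clearly differ: the same change on two cores in this assay, an at least 3.4-fold higher number (0.53 log units; beyond the scatter) from compound 1 to compound 2 and a 16-fold lower number (1.21 log units; beyond the scatter) from compound 3 to compound 4, at least 56-fold (1.74 log units) apart, beyond the scatter of two such steps. Among these four compounds, the outcome of the change therefore cannot be read from the group on the amine nitrogen alone, and the core of compound 1 and the core of compound 3 have to be taken into account.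

As far as these compounds go, compound 2 gives > 910000 nM, which is a limit of the assay and not a number, so the full size of the step on the core of compound 1 remains open. Also open, from the compounds shown here alone, is how a plain phenyl group, or a phenyl ring carrying an amine or a carboxylic acid, would behave at this position on each of the two cores.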